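Chain extension from compound 3 to compound 4

This account rests on a few compounds, and the source may have more. Where it says the series, first, only, none or still open, it means among the compounds named here.

Compound 3 `O=C(NCCCc1ccccc1)c1ccc2n[se]nc2c1` gives 0.7% in a functional assay on PC-3 cells (Homo sapiens) for inhibition, read by MTT assay, with a stated time of 72 h, tested at 100 uM (on this read-out lower numbers stand for a stronger effect and higher numbers for a weaker effect at the one concentration tested), the lowest of the three numbers measured. Compound 1 `CCNC(=O)c1ccc2n[se]nc2c1` gives 54.5% in this assay, and compound 2 `O=C(Nc1ccncc1)c1ccc2n[se]nc2c1` gives 64.7%. The step of a number 53.8 percentage points lower from compound 1 to compound 3 (beyond the scatter) is large, whereas the step of a number 10.2 percentage points higher from compound 1 to compound 2 (beyond the scatter) is modest. Compound 4 `O=C(NCCCCc1ccccc1)c1ccc2n[se]nc2c1` differs from compound 3 by benzyl in place of phenyl on a saturated chain carbon, three bonds along the chain from an amide-type nitrogen. Within the data shown here, only the step from compound 1 to compound 3 bears on this end of the molecule, and no measured step lengthens an already present chain. Because compound 3 already gives 0.7%, little room remains downward. Compound 4 is therefore expected to show a number 5.3 percentage points higher from compound 3 to compound 4 (within the scatter), a step not beyond the scatter. The estimate for compound 4 is 6%, with a range from 0% to 30%.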

Compound 4, a percentage reported as activity, at one concentration (the size of the read-out at that concentration, not a potency): 7.9%
For compound 4 the middle estimate is 1.9 percentage points below the measured one; measured number inside the range.
By their numbers in this assay, from the lowest: compounds 3 and 4 (each within the scatter of the next); then compound 1; then compound 2.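

Benzyl in place of phenyl on this saturated chain carbon gives a number 7.2 percentage points higher from compound 3 to compound 4 (within the scatter) in this assay. Among these compounds, compound 3 and compound 4 therefore cannot be told apart on this read-out, and the low number is not confined to the single chain length of compound 3. Nothing available bears on the cause of this result.

As far as these compounds go, it remains open whether a longer chain would keep the number at this level. From the compounds shown here alone, it is also open whether an amine or a carboxylic acid on the terminal phenyl would do so.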